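This account rests on a few compounds, and the source may have more. Where it says the series, first, only, none or still open, it means among the compounds named here.

Compound 1 `O=C(O)CCc1ccc(C#Cc2ccnc3cc(Cl)ccc23)cc1`: 125%. Compound 2 `O=C(O)CCc1ccc(C#Cc2ccnc(-c3ccccc3)c2)cc1`: 97%. Compound 3 `O=C(O)CCc1ccc(C#Cc2ccnc(Cl)n2)cc1`: 131%.

In an in vitro functional assay on 1321-N1 cells for agonist activity at Free fatty acid receptor 1 (Homo sapiens), read by fluorescence, spectrophotometry and calcium flux (on this read-out higher numbers stand for larger maximal responses and lower numbers for smaller maximal responses), compound 2 stands lowest of the three numbers. Compound 1 lies higher by a margin beyond the scatter, and compound 3 lies higher still, also beyond the scatter. Compound 4 `COc1cc(C#Cc2ccc(CCC(=O)O)cc2)ccn1` has not been measured. It differs from compound 2 in one place: methoxy in place of phenyl on an aromatic carbon, on the six-membered aromatic ring with one nitrogen, next to the ring nitrogen. Going by the values given here, no measured pair shows this change, so the step can only be weighed against the spread of the three values, in which compound 1 gives 125% and compound 3 gives 131%. The step from compound 2 to compound 4 is expected to be a moderate rise, a number 18 percentage points higher from compound 2 to compound 4 (beyond the scatter). Compound 4 is therefore estimated at 115%, within a range from 90% to 135%.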

Compound 4, largest response reached (reported as efficacy), in percent of the reference or control that the assay uses: 98%
Compound 4: the middle estimate sits 17 percentage points above what was measured; measured number inside the range.
By their numbers in this assay, from the lowest: compounds 2 and 4 (each within the scatter of the next); then compounds 1 and 3 (each within the scatter of the next).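

In this assay, methoxy in place of phenyl on this aromatic carbon, next to the ring nitrogen, gives a number 1 percentage points higher from compound 2 to compound 4 (within the scatter). At this position, then, a group of 2 heavy atoms with 1 hydrogen-bond acceptor can stand in for the six-membered aromatic ring of carbon only without a shift beyond the scatter. The data shown offer no explanation for this.

From the compounds shown here alone, it remains open whether an amine or a longer ether chain such as ethoxy at this same carbon would also stay within the scatter of compound 2.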